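A few compounds are considered here, and "the series" means these few. Any claim that something is new, unique, unknown or untested is made for them only; others in the source may bear on it.

Measured so far in a functional assay on HepG2 cells (Homo sapiens) for antiproliferative activity, read by MTT assay, with a stated time of 48 h; on this read-out higher numbers stand for weaker inhibition and lower numbers for stronger inhibition 
- compound 1 (`COc1ccc(/C=C/c2cc(OC)cc(OC)c2/C=C/C(=O)c2cccc(Br)c2)cc1`) gives 13 ug/mL 
- compound 2 (`COc1ccc(/C=C/c2cc(OC)cc(OC)c2/C=C/C(=O)c2ccc(C(F)(F)F)cc2)cc1`) gives 18.7 ug/mL 

The value of compound 2 at 18.7 ug/mL and that of compound 1 at 13 ug/mL lie within the usual scatter of each other. Compound 3 (`CCOc1ccc(C(=O)/C=C/c2c(/C=C/c3ccc(OC)cc3)cc(OC)cc2OC)cc1`) keeps the shared core and differs from compound 2 in one place, with ethoxy in place of trifluoromethyl on an aromatic carbon. Within the data shown here, only one measured step bears on this. It exchanged one substituted phenyl for another on a carbonyl carbon, and it was small (a 1.4-fold higher number from compound 1 to compound 2 (0.16 log units; within the scatter)). Among the measured compounds shown here, no measured compound carries ethoxy, so this is thin guidance, and no shift beyond the scatter is expected in either direction. The expected step is small (a 1.2-fold lower number from compound 2 to compound 3 (0.07 log units; within the scatter)). The estimate for compound 3 is 16 ug/mL, with an expected range from 7 ug/mL to 35 ug/mL.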

Compound 3, half-maximal inhibitory concentration: 8 ug/mL
The estimate for compound 3 lay 2.0-fold (0.30 log units) above the measured number; measured number inside the range.
By their numbers in this assay, from the lowest: compounds 3, 1 and 2 (each within the scatter of the next, the first and the last beyond it).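

In this assay, among these compounds, the change at this spot, para to a large group, gives the first step that clears the usual scatter (a 2.3-fold lower number from compound 2 to compound 3 (0.37 log units; beyond the scatter)), so exchanging the group on this aromatic carbon can shift the number, if only modestly. The other new step (a 1.6-fold lower number from compound 1 to compound 3 (0.21 log units; within the scatter)) stays within the scatter, so 4-ethoxyphenyl and 3-bromophenyl cannot be ranked against each other on these numbers. No available evidence explains why the ethoxy compound gives the lower number.

Going by these compounds, whether this shift is specific to ethoxy remains open, since a longer chain such as propoxy might give a similar number or a different one at the same position. It is also unknown how an amine or a carboxylic acid there would compare.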